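This account rests on a few compounds, and the source may have more. Where it says the series, first, only, none or still open, it means among the compounds named here.

Measured in an assay for inhibition of Alpha amylase (Homo sapiens), with a stated time of 10 min; on this read-out lower numbers stand for stronger inhibition and higher numbers for weaker inhibition:
compound 1 `COc1ccc(/C=C2/C(=O)N(c3ccc(Cl)cc3)N=C2C)cc1OC` gives 2030 nM
compound 2 `COc1ccc(/C=C2/C(=O)N(c3ccc(Cl)cc3)N=C2C)c(OC)c1OC` gives 2100 nM
compound 3 `COc1ccc(/C=C2/C(=O)N(c3ccc(Cl)cc3)N=C2C)c(Cl)c1OC` gives 1970 nM

Compound 1 sits in the middle of a narrow band: a 1.0-fold higher number from compound 1 to compound 2 (0.01 log units; within the scatter) and a 1.0-fold lower number from compound 1 to compound 3 (0.01 log units; within the scatter) both lie within the scatter, and so does a 1.1-fold lower number from compound 2 to compound 3 (0.03 log units; within the scatter). Nothing in this set has moved the read-out.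

Compound 4 `COc1ccc(/C=C2/C(=O)N(c3ccc(Cl)cc3)N=C2C)cc1Br` differs from compound 1 by bromo in place of methoxy on an aromatic carbon. Within the data shown here, the steps that bear on a halogen entering this ring are a 1.0-fold lower number from compound 1 to compound 3 (0.01 log units; within the scatter) and a 1.1-fold lower number from compound 2 to compound 3 (0.03 log units; within the scatter), neither of them beyond the scatter. The expectation for a 1.0-fold lower number from compound 1 to compound 4 (0.01 log units; within the scatter) is therefore no step beyond the scatter. Compound 4 is estimated at 2000 nM, with a range from 1000 nM to 4000 nM.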

Compound 4, half-maximal inhibitory concentration: 1920 nM
Estimate against measurement, compound 4: 1.0-fold (0.02 log units) above; the measured number falls inside the stated range.
By their numbers in this assay, from the lowest: compounds 4, 3, 1 and 2 (each within the scatter of the next).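

The earlier compounds shown here all keep the methoxy at this place, whereas compound 4 gives it up: bromo replaces it, with one heavy atom instead of two and no hydrogen-bond acceptor instead of one. The result is a 1.1-fold lower number from compound 1 to compound 4 (0.02 log units; within the scatter), so in this series the read-out does not depend on that methoxy, and a halogen is accepted here as well as on the positions already changed. No supporting data bear on why this holds.

From the compounds shown here alone, whether an amine, a carboxylic acid or a longer alkoxy chain at this place would shift the read-out remains open. So does the effect of replacing the remaining methoxy group.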